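Dichlorophenyl urea: expected tolerance in the liver-cell assay

The source may report more compounds than this note shows. Statements on the series, on what has been measured and on what is new or still open speak of the compounds shown alone.

For the measured compounds named here, compound 2 `COc1cc2cc(Oc3ccc(NC(=O)Nc4ccc(Cl)c(C(F)(F)F)c4)cc3)c(C)nc2cc1OC` is the only compound of the series with a number in a functional assay on HCC 2998 cells (Homo sapiens) for inhibition, read by sulforhodamine B assay, with a stated time of 48 h; a higher number here means that more compound is tolerated, a lower number that less compound is tolerated: compound 2 gives 13600 nM. Compound 1 `COc1cc2cc(Oc3ccc(NC(=O)Nc4cccc(C(F)(F)F)c4)cc3)c(C)nc2cc1OC` sits at the limit of this assay, compound 1 giving > 50000 nM (the limit of > 50000 nM in this assay, at which 1 of the 2 values shown sits). Going by the values given here, the single measured step, an at least 3.6-fold lower number from compound 1 to compound 2 (0.56 log units; beyond the scatter), changes a different position and does not repeat the move to compound 3 `COc1cc2cc(Oc3ccc(NC(=O)Nc4ccc(Cl)c(Cl)c4)cc3)c(C)nc2cc1OC`, which is chloro in place of trifluoromethyl on an aromatic carbon. Among the compounds with values here, with no step of the same kind measured, no change beyond the scatter is expected, and compound 3 is estimated at 18000 nM (6000 nM to 50000 nM), a step of a 1.3-fold higher number from compound 2 to compound 3 (0.12 log units; within the scatter).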

Compound 3, concentration lethal to 50% of the cells: > 100000 nM
Compound 3 ended at the assay's limit (the forecaster's own chance of this, stated with the estimate: 25%); at least 5.5-fold (0.74 log units) between middle value and limit.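

Chloro in place of trifluoromethyl, on the carbon ortho to a chloro group, gives an at least 7.3-fold higher number from compound 2 to compound 3 (0.86 log units; beyond the scatter) in this assay, so the group at this position bears on the read-out as well as the chloro group added in compound 2. Compound 3 stands at a limit of the assay, not at a number: the limit of > 100000 nM in this assay, at which 1 of the 3 values shown sits.

The step from compound 1 to compound 3 cannot be read. Going by these compounds, the true value of compound 3 stays open, as does how a methyl, a methoxy or an amine at this position would compare with chloro and trifluoromethyl.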